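The source may report more compounds than this note shows. Statements on the series, on what has been measured and on what is new or still open speak of the compounds shown alone.

Compound 2 `COc1cc(-c2nn(-c3cccc(NC(=O)c4ccc(Cl)c(C(F)(F)F)c4)c3)cc2-c2ccncc2)ccc1Cl` and compound 1 `O=C(Nc1cccc(-n2cc(-c3ccncc3)c(-c3ccc(Cl)c(O)c3)n2)c1)Nc1ccc(Cl)c(Cl)c1` share a core. In a functional assay on A549 cells (Homo sapiens) for inhibition, read by sulforhodamine B assay, with a stated time of 48 h (a lower number here means that less compound is tolerated, a higher number that more compound is tolerated), compound 1 gives only a limit of the assay, > 32500 nM. In this assay compound 2 likewise gives only a limit, > 32500 nM. Both values sit at the limit of > 32500 nM in this assay, at which 2 of the 2 values shown sit, so compound 2 stands nowhere distinct among the numbers shown. Compound 3 `COc1cc(-c2nn(-c3cccc(NC(=O)c4cccc(C(F)(F)F)c4)c3)cc2-c2ccncc2)ccc1Cl` differs from compound 2 by hydrogen in place of chloro on an aromatic carbon. Going by the values given here, with no measured step between compounds to draw on, the change from compound 2 to compound 3 is expected to be a number no higher from compound 2 to compound 3 (the limit leaves the size open), none beyond the scatter. Compound 3 is therefore estimated at 32500 nM, between 15000 nM and 100000 nM.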

Compound 3, concentration lethal to 50% of the cells: > 50000 nM
Compound 3: a limit, no number (the forecaster's own chance of this, stated with the estimate: 75%); middle value at least 1.5-fold (0.18 log units) away from the limit.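

Going by these compounds alone, compound 2 and compound 3 both give only limits in this assay, so no step between them can be read. The compounds shown leave open whether hydrogen in place of chloro changes the value at all.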